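The source may hold more compounds than are shown below. What is called first, only, known or untested is meant among the compounds shown, and "the series" means these compounds.

Series notes. Compound 1 `O=C(O)CCc1ccncc1-c1ccc2ccccc2c1` carries a 2-carboxyethyl chain on an aromatic carbon of the shared core. In a functional assay on HCT-116 cells (Homo sapiens) for inhibition, read by MTT assay, with a stated time of 72 h (on this read-out lower numbers stand for stronger inhibition of growth and higher numbers for weaker inhibition of growth), compound 1 gives only a limit, > 30000 nM; this is the limit of > 30000 nM in this assay, at which 1 of the 3 values shown sits. Compound 2 `CNC(=O)/C=C/c1ccncc1-c1ccc2ccccc2c1` has 2-(methylcarbamoyl)ethenyl in its place, and in this assay compound 2 gives 6550 nM. Among the compounds with values here, the step of an at least 4.5-fold lower number from compound 1 to compound 2 (0.66 log units; beyond the scatter) is the only measured step in the set. Compound 3 `O=C(O)COc1ccncc1-c1ccc2ccccc2c1` has no result: in this assay compound 3 gives "not determined" (no result reported). Compound 2 therefore stands as the only number shown; one further value is a limit and one entry has no number.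

Compound 4 `CN1CCN(C(=O)/C=C/c2ccncc2-c2ccc3ccccc3c2)CC1` differs from compound 2 at the carbonyl carbon: 4-methylpiperazin-1-yl in place of methylamino on a carbonyl carbon. Within the data shown here, the one measured step, from compound 1 to compound 2, changes the chain and the carbonyl group together and leaves the amide nitrogen untouched, so it does not speak to the present change. Among the measured compounds shown here, no measured step addresses the group on the amide nitrogen. The step from compound 2 to compound 4 is therefore expected to stay within the scatter: a 1.1-fold lower number from compound 2 to compound 4 (0.04 log units; within the scatter). Compound 4 is expected to give 6000 nM in this assay, with a range from 2000 nM to 20000 nM.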

Compound 4, concentration for 50% growth inhibition: > 30000 nM
Compound 4: a limit, no number (the forecaster's own chance of this, stated with the estimate: 10%); at least 5.0-fold (0.69 log units) between middle value and limit.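

Within the data shown here, the place on the carbonyl carbon is sensitive to the group it carries: with the chain kept, 4-methylpiperazin-1-yl in place of methylamino gives an at least 4.5-fold higher number from compound 2 to compound 4 (0.66 log units; beyond the scatter) in this assay, the first measured step that concerns this group alone. In this assay compound 4 gives > 30000 nM, which is a limit and not a number, so the step has a lower bound and no exact size. Only compound 2 still carries a number in the set, and compound 1 and compound 4 now share the same limit: the limit of > 30000 nM in this assay, at which 2 of the 4 values shown sit.

The change replaces methylamino with a larger group, brings in a six-membered non-aromatic ring and removes the amide hydrogen, and the compounds shown do not tell these parts of the change apart. A dimethylamino group on the carbonyl carbon would remove the amide hydrogen without adding a ring, while a longer chain on the amide nitrogen, such as propylamino, would keep that hydrogen and add size, and neither case can be judged from the values shown.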